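Cytotoxicity notes on a nucleoside series with varied side groups

The compounds below may be only part of what the source reports. "The series", "measured", "known", "first", "only" and "open" are said of these compounds alone.

Measured so far in a functional assay on Huh-7 cells (Homo sapiens) for cytotoxicity, read by MTT assay, with a stated time of 3 days; a higher number here means that more compound is tolerated, a lower number that less compound is tolerated:
compound 1, `OC[C@H]1O[C@@H](n2cnc3c(CS)ncnc32)C[C@@H]1O`: 41000 nM
compound 2, `OC[C@H]1O[C@@H](n2cnc3c(Cn4ccc5ccccc54)ncnc32)[C@H](O)[C@@H]1O`: > 250000 nM, a limit
compound 3, `CC(=O)N(Cc1ncnc2c1ncn2[C@@H]1O[C@H](CO)[C@@H](O)[C@H]1O)C1CCCCC1`: > 100000 nM, a limit

For compound 2 this assay gives only a limit, (the limit of > 250000 nM in this assay, at which 1 of the 3 values shown sits). Compound 3 likewise sits at a limit, (the limit of > 100000 nM in this assay, at which 1 of the 3 values shown sits). Only compound 1 has a number. Compound 4, `CN(Cc1ccccc1)Cc1ncnc2c1ncn2[C@@H]1O[C@H](CO)[C@@H](O)[C@H]1O`, differs from compound 2 by benzyl(methyl)amino in place of 1H-indol-1-yl on a saturated chain carbon bound to an aromatic carbon. Going by the values given here, no step between two measured compounds covers this change, so the size of any shift is open. The step of an at least 1.2-fold lower number from compound 2 to compound 4 (0.09 log units; that floor lies within the scatter) is expected to be none beyond the scatter, with no direction fixed, since compound 2 offers only a limit. The estimate for compound 4 is 200000 nM, with a range from 60000 nM to 600000 nM, and a limit rather than a number is quite likely.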

Compound 4, half-maximal cytotoxic concentration: 9000 nM
Beside the measured number, compound 4's estimate is 22-fold (1.35 log units) above it, outside the stated range (below it).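

In this assay, the group on a saturated chain carbon bound to an aromatic carbon clearly matters: an at least 27-fold lower number from compound 2 to compound 4 (1.44 log units; beyond the scatter) is a large step. The two groups match in their counts of heavy atoms, donors and acceptors, so those counts alone do not separate 1H-indol-1-yl from benzyl(methyl)amino here. The step is only a floor because compound 2 sits at a limit: the limit of > 250000 nM in this assay, at which 1 of the 4 values shown sits.

Which part of benzyl(methyl)amino goes with the lower number remains open. Dimethylamino or piperidin-1-yl at the same place would show whether the benzyl ring is needed for it.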